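A few compounds are considered here, and "the series" means these few. Any claim that something is new, unique, unknown or untested is made for them only; others in the source may bear on it.

Compound 1 `CCOC(=O)C12C(=O)OCC=C1COC2c1ccccc1`: > 1000000 nM
Compound 2 `CCOC(=O)C12C(=O)OCC=C1COC2c1ccc(Cl)cc1`: > 1000000 nM
Compound 3 `CCOC(=O)C12C(=O)OCC=C1COC2c1ccc(OC)cc1`: 9300 nM

The three compounds share one core and differ only in the group on the aromatic ring. In a functional assay on A549 cells (Homo sapiens) for cytotoxicity, read by MTT assay (a higher number here means a weaker inhibitor, a lower number a stronger inhibitor), compound 1 gives > 1000000 nM, which is a limit of the assay and not a number. Compound 2 gives > 1000000 nM in this assay, again a limit. Compounds 1 and 2 thus both sit at the limit of > 1000000 nM in this assay, at which 2 of the 3 values shown sit. Compound 3 gives 9300 nM in this assay and is the only one of the three with a measured number. The step of an at least 100-fold lower number from compound 1 to compound 3 (2.03 log units; beyond the scatter) and the step of an at least 100-fold lower number from compound 2 to compound 3 (2.03 log units; beyond the scatter) are both large, while a step that the two limits leave unreadable from compound 1 to compound 2 is not readable.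

Compound 4 `CCOC(=O)C12C(=O)OCC=C1COC2c1ccc([N+](=O)[O-])cc1` differs from compound 3 by nitro in place of methoxy on an aromatic carbon. Among the compounds with values here, no measured step replaces methoxy by nitro; the measured steps show only that methoxy gives a far lower number in this assay than hydrogen or chloro, and nitro is neither of these. The safest expectation is that removing the methoxy loses much of what it brought, so the step of a 16-fold higher number from compound 3 to compound 4 (1.21 log units; beyond the scatter) is expected to run upward, back towards the limit. Compound 4 is therefore estimated at 150000 nM, with a range from 10000 nM to 1000000 nM.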

Compound 4, half-maximal inhibitory concentration: 36800 nM
Estimate against measurement, compound 4: 4.1-fold (0.61 log units) above; the measured number falls inside the stated range.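

In this assay, within the data shown here, methoxy is not the only group at this place on the aromatic ring that moves the result away from the limit, as nitro does the same: the change from chloro gives an at least 27-fold lower number from compound 2 to compound 4 (1.43 log units; beyond the scatter), and the change from hydrogen gives an at least 27-fold lower number from compound 1 to compound 4 (1.43 log units; beyond the scatter). Exchanging the two groups that give measured numbers costs far less than either of those gains, with a 4.0-fold higher number from compound 3 to compound 4 (0.60 log units; beyond the scatter), a modest step but one still beyond the scatter, so methoxy keeps an edge over nitro while much of the gain survives without it. The split among the four compounds is now two against two, with hydrogen and chloro on one side, and compound 1 and compound 2 remain at a limit of the assay, which is not a number: the limit of > 1000000 nM in this assay, at which 2 of the 4 values shown sit.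

The compounds shown leave open whether an amine, a carboxylic acid or a longer chain such as ethoxy at this place would give a measured number, and how any of these would stand against methoxy and nitro. They also leave open whether methoxy or nitro would keep its number at another place on the aromatic ring.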